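This account rests on a few compounds, and the source may have more. Where it says the series, first, only, none or still open, it means among the compounds named here.

Measured compounds:
compound 1 `C=Cc1ccsc1CN[C@@H]1C[C@H]2C[C@@H]([C@H]1C)C2(C)C` 50000 nM
compound 2 `C[C@H]1[C@H](NCc2ccc(Br)s2)C[C@H]2C[C@@H]1C2(C)C` 43000 nM
compound 3 `C[C@H]1[C@H](NCc2cnccn2)C[C@H]2C[C@@H]1C2(C)C` > 100000 nM

In an ADME assay on MDCK cells (Canis lupus familiaris) for cytotoxicity, read by microscopy, with a stated time of 48 h (a higher number here means that more compound is tolerated, a lower number that less compound is tolerated), compound 1 gives 50000 nM and compound 2 gives 43000 nM, two values within the scatter of each other. Compound 3 reaches only a limit of the assay, > 100000 nM, as noted in the limit of > 100000 nM in this assay, at which 1 of the 3 values shown sits. Compound 4 `Cc1csc(CN[C@@H]2C[C@H]3C[C@@H]([C@H]2C)C3(C)C)n1` is the next compound, with the change (4-methyl-1,3-thiazol-2-yl in place of pyrazin-2-yl on a saturated chain carbon bound to an amine nitrogen). Among the compounds with values here, the only step that bears on it is an at least 2.3-fold higher number from compound 2 to compound 3 (0.36 log units; beyond the scatter), where a five-membered sulfur-containing aromatic ring gave way to the pyrazinyl; compound 4 partly reverses that, bringing a five-membered ring back. The expected step of an at least 1.4-fold lower number from compound 3 to compound 4 (0.15 log units; that floor lies within the scatter) is therefore a modest fall, roughly toward the thiophene values. Compound 4 is estimated at 70000 nM, between 35000 nM and 150000 nM.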

Compound 4, minimum cytotoxic concentration: > 100000 nM
Compound 4 gave a limit, no number (the forecaster's own chance of this, stated with the estimate: 35%); middle value at least 1.4-fold (0.15 log units) away from the limit.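

In this assay compound 4 gives > 100000 nM, a limit of the assay and not a number. With 4-methyl-1,3-thiazol-2-yl in place of 5-bromothiophen-2-yl on a saturated chain carbon bound to an amine nitrogen, there is an at least 2.3-fold higher number from compound 2 to compound 4 (0.36 log units; beyond the scatter), so a five-membered aromatic ring at this position can also give this rise, not only the six-membered pyrazin-2-yl. The step from compound 3 to compound 4 cannot be read, because both values are limits: the limit of > 100000 nM in this assay, at which 2 of the 4 values shown sit.

From the compounds shown here alone, how far either compound lies past the limit remains open. So does whether a phenyl ring or an unsubstituted thiazol-2-yl here would also reach it.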